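Cytotoxicity notes on a uracil series

The source may report more compounds than this note shows. Statements on the series, on what has been measured and on what is new or still open speak of the compounds shown alone.

Measured compounds:
compound 1 `Cc1ccc(Nc2cn(Cc3ccc(Cl)cc3Cl)c(=O)[nH]c2=O)cc1`, an ADME assay on CEM-SS cells (Homo sapiens) for cytotoxicity, read by XTT assay; on this read-out lower numbers stand for higher toxicity in this test and higher numbers for lower toxicity in this test: "not determined" (no result reported)
compound 2 `O=c1[nH]c(=O)n(Cc2cccc(Oc3ccccc3)c2)cc1Nc1ccccc1`, this assay: > 100000 nM

Compound 1 stands without a number in this assay; its result reads "not determined" (no result reported). For compound 2 the value > 100000 nM is a limit of the assay, not a number, as the line the limit of > 100000 nM in this assay, at which 1 of the 2 values shown sits, records. Compound 3 `O=c1[nH]c(=O)n(Cc2ccc(Cl)cc2Cl)cc1NCc1ccccc1` differs from compound 1 by benzyl in place of 4-methylphenyl on a nitrogen on an aromatic ring. Among the measured compounds shown here, with no measured step between the compounds, no shift beyond the scatter is expected. Compound 3 is estimated at 100000 nM, within 30000 nM to 300000 nM.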

Compound 3, half-maximal cytotoxic concentration: > 100000 nM
Compound 3: no number, only a limit; the forecaster's own chance of this, stated with the estimate: 70%; the middle value sits exactly at the limit.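

No step can be read from compound 1 to compound 3: compound 1 has no number, and compound 3 has only a limit. Still open, on these data alone, is how benzyl in place of 4-methylphenyl shifts the read-out in this assay.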